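The source may hold more compounds than are shown below. What is called first, only, known or untested is meant among the compounds shown, and "the series" means these compounds.

Measured so far in an ADME assay on HEK-293T cells (Homo sapiens) for cytotoxicity, read by MTT assay, with a stated time of 24 h; a higher number here means that more compound is tolerated, a lower number that less compound is tolerated
- compound 1 `Cc1ccc(-c2nn(-c3ccccc3)cc2-c2nc3ccccc3[nH]2)cc1` gives 187000 nM
- compound 2 `FC(F)(F)c1ccc(-c2nn(-c3ccccc3)cc2-c2nc3ccccc3[nH]2)cc1` gives 167000 nM
- compound 3 `O=S(=O)(c1ccc(C(F)(F)F)cc1)n1c(-c2cn(-c3ccccc3)nc2-c2ccc(F)cc2)nc2ccccc21` gives 241000 nM

Compound 2 stands within the scatter of both compound 1 and compound 3. Next comes compound 4 `COc1ccc(S(=O)(=O)n2c(-c3cn(-c4ccccc4)nc3-c3ccc(C(F)(F)F)cc3)nc3ccccc32)cc1`, which is compound 2 with (4-methoxyphenyl)sulfonyl in place of hydrogen on an aromatic nitrogen. Within the data shown here, the only measured step (a 1.1-fold lower number from compound 1 to compound 2 (0.05 log units; within the scatter)) stays within the scatter and lies at a different place, so it says little about this change. Compound 3 (241000 nM) also carries a sulfonyl group on that nitrogen, and its number is within the scatter of compound 2. No step beyond the scatter is therefore expected in this assay. The expected step is small (a 1.2-fold higher number from compound 2 to compound 4 (0.08 log units; within the scatter)). Compound 4 is estimated at 200000 nM (expected range 110000 nM to 350000 nM).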

Compound 4, half-maximal cytotoxic concentration: > 300000 nM
Compound 4 ended at the assay's limit (the forecaster's own chance of this, stated with the estimate: 10%); middle value at least 1.5-fold (0.17 log units) from the limit.
By their numbers in this assay, from the lowest: compounds 2, 1 and 3 (each within the scatter of the next). At a limit, above all of these: compound 4.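

In this assay, among these compounds, (4-methoxyphenyl)sulfonyl in place of hydrogen on the aromatic nitrogen gives an at least 1.7-fold higher number from compound 2 to compound 4 (0.25 log units; that floor lies within the scatter), the first one-place reading at this nitrogen. The change does not lower the number. Compound 4 gives > 300000 nM, which is a limit, so the step has only a floor: the limit of > 300000 nM in this assay, at which 1 of the 4 values shown sits.

Still open, from the compounds shown here alone, is the true size of this step. Also open, going by these compounds, is whether an amine or a carboxylic acid in place of the methoxy group would leave the number in this assay equally high.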